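A few compounds are considered here, and "the series" means these few. Any claim that something is new, unique, unknown or untested is made for them only; others in the source may bear on it.

Measured compounds:
compound 1, `c1ccc2c(c1)CN[C@@H](CN(CCCCN(Cc1ccncc1)Cc1ccncc1)[C@H]1CCCc3cccnc31)C2`: > 30000 nM
compound 2, `c1ccc2c(c1)CN[C@@H](CN(CCCCNC1CCCCC1)[C@H]1CCCc3cccnc31)C2`: > 30000 nM
compound 3, `CC1(C)CCC(NCCCCN(C[C@H]2Cc3ccccc3CN2)[C@H]2CCCc3cccnc32)CC1`: > 30000 nM

In a functional assay on cells for agonist activity at C-X-C chemokine receptor type 4 (Homo sapiens), read by fluorescence and calcium flux, with a stated time of 90 s (a lower number here means that less compound is needed, a higher number that more compound is needed for the effect), compound 2 gives only a limit, > 30000 nM. Compound 1 in this assay likewise gives a limit, > 30000 nM. Compound 3 in this assay also gives a limit, > 30000 nM. Among the measured compounds shown here, the one measured step that changes a single place, a step that the two limits leave unreadable from compound 2 to compound 3, is therefore unreadable, since (the limit of > 30000 nM in this assay, at which 3 of the 3 values shown sit). Compound 4, `CC(C)(CN)CCN(C[C@H]1Cc2ccccc2CN1)[C@H]1CCCc2cccnc21`, differs from compound 2 by 1-(aminomethyl)-1-methylethyl in place of 2-(cyclohexylamino)ethyl on a saturated chain carbon, two bonds along the chain from an amine nitrogen. No measured step bears readably on this change, so no direction can be drawn from the numbers shown. Compound 4 is expected to give about 30000 nM, in the range 8000 nM to 100000 nM, most probably again only a limit. The implied step is estimated as a number no higher from compound 2 to compound 4 (the limit leaves the size open).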

Compound 4, half-maximal effective concentration: > 30000 nM
Compound 4 ended at the assay's limit (the forecaster's own chance of this, stated with the estimate: 75%); the middle value sits exactly at the limit.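

No new step can be read from compound 4, because compound 2, compound 3 and compound 4 all end at a limit and not at a number: the limit of > 30000 nM in this assay, at which 4 of the 4 values shown sit.

The compounds shown leave open whether any change on this shared core gives a readable half-maximal effective concentration in this assay.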